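The source may hold more compounds than are shown below. What is called first, only, known or untested is meant among the compounds shown, and "the series" means these compounds.

In a functional assay on HT-29 cells (Homo sapiens) for inhibition, read by CellTiter-Glo, with a stated time of 72 h (a lower number here means that less compound is tolerated, a higher number that more compound is tolerated), compound 2 `CC1=C(C(C)C(=O)NCCN2CCCC2)c2cc(F)ccc2/C1=C\c1ccc([S+](C)[O-])cc1` gives 13700 nM, and compound 1 `CC1=C(C(C)C(=O)N(CCNC(C)C)C(C)C)c2cc(F)ccc2/C1=C\c1ccc([S+](C)[O-])cc1` gives 8060 nM; the step of a 1.7-fold higher number from compound 1 to compound 2 (0.23 log units; within the scatter) separates them. Compound 3 `CC1=C(C(C)C(=O)N2CCN(CCN(C)C)CC2)c2cc(F)ccc2/C1=C\c1ccc([S+](C)[O-])cc1` carries 4-(2-(dimethylamino)ethyl)piperazin-1-yl in place of (2-(pyrrolidin-1-yl)ethyl)amino on a carbonyl carbon. Within the data shown here, the only comparison that bears on this change is the swap of the amide substituent from compound 1 to compound 2, which produced a 1.7-fold higher number from compound 1 to compound 2 (0.23 log units; within the scatter), within the scatter. Compound 3 is therefore expected to show no shift beyond the scatter in this assay, and its estimated value is 12000 nM, with a range from 4000 nM to 36000 nM, corresponding to an expected step of a 1.1-fold lower number from compound 2 to compound 3 (0.06 log units; within the scatter).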

Compound 3, half-maximal cytotoxic concentration: 38400 nM
Beside the measured number, compound 3's estimate is 3.2-fold (0.51 log units) below it; measured number outside the range, above it.
By their numbers in this assay, from the lowest: compounds 1 and 2 (each within the scatter of the next); then compound 3.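

Unlike the earlier swap on this carbonyl carbon, this change moves the number beyond the scatter in this assay. The 4-(2-(dimethylamino)ethyl)piperazin-1-yl group gives a modest rise against (2-(pyrrolidin-1-yl)ethyl)amino (a 2.8-fold higher number from compound 2 to compound 3 (0.45 log units; beyond the scatter)) and against isopropyl(2-(isopropylamino)ethyl)amino (a 4.8-fold higher number from compound 1 to compound 3 (0.68 log units; beyond the scatter)). Nothing measured here explains the rise.

From the compounds shown here alone, whether the higher number depends on the whole 4-(2-(dimethylamino)ethyl)piperazin-1-yl group or on its ring alone remains open. A morpholine or an unsubstituted piperazine on the carbonyl carbon could separate the ring from the dimethylaminoethyl chain.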